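Extending a methoxy toward phenethyloxy in an inducible NOS series

This account rests on a few compounds, and the source may have more. Where it says the series, first, only, none or still open, it means among the compounds named here.

Compound 1, `COc1ccnc(CSC)c1OC`: in an assay on isolated protein for inhibition of Nitric oxide synthase, inducible (Homo sapiens), read by scintillation counting (on this read-out lower numbers stand for stronger inhibition and higher numbers for weaker inhibition), compound 1 gives > 100000 nM, which is a limit of the assay rather than a number.
Compound 2, `COc1ccnc(CCc2nc3c(OC)ccnc3[nH]2)c1`: in this assay compound 2 gives 776 nM.

For the measured compounds named here, compound 2 holds the only numbered value in this assay; the other entry sits at the limit of > 100000 nM in this assay, at which 1 of the 2 values shown sits, and is a limit only.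

Compound 3, `COc1ccnc(CCc2nc3c(OCCc4ccccc4)ccnc3[nH]2)c1`, is not yet measured. It differs from compound 2 by benzyl in place of hydrogen on a saturated chain carbon bound to an oxygen on an aromatic ring, so that a methoxy becomes a phenethyloxy.

Going by the values given here, no step between measured compounds exists to calibrate this change, so the expectation for the step from compound 2 to compound 3 is a modest shift, estimated at a 1.9-fold higher number from compound 2 to compound 3 (0.29 log units; within the scatter), toward somewhat weaker inhibition but possibly within the scatter. Compound 3 is therefore estimated at 1500 nM, with a range from 300 nM to 8000 nM.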

Compound 3, half-maximal inhibitory concentration: 724 nM
The estimate for compound 3 lay 2.1-fold (0.32 log units) above the measured number; the measured number falls inside the stated range.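

In this assay, the step of a 1.1-fold lower number from compound 2 to compound 3 (0.03 log units; within the scatter) shows that swapping methoxy for phenethyloxy leaves the reading within the usual scatter. The earlier compounds shown here gave no view of this place, and now it is clear that a saturated chain carbon bound to an oxygen on an aromatic ring can carry a benzyl without a measurable loss of inhibition. Nothing in the data shown explains why the larger group leaves the number where it is.

On these data alone, only methoxy and phenethyloxy appear at this place, so the effect of a chain longer than phenethyl, or of an amine or a carboxylic acid at the end of the chain, remains open. Also open, as far as these compounds go, is whether a plain propyl chain would read the same as phenethyl, which would show whether the benzene ring itself matters.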